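Deoxynucleoside series: removing the benzylsulfanyl group

A few compounds are considered here, and "the series" means these few. Any claim that something is new, unique, unknown or untested is made for them only; others in the source may bear on it.

Measured so far:
Compound 1 `[N-]=[N+]=Nc1nccc2c1ncn2[C@H]1C[C@H](O)[C@@H](CO)O1` gives in a functional assay (Homo sapiens) for inhibition of Nucleic Acid, tested at 100 uM (on this read-out higher numbers stand for more inhibition at the one concentration tested (going by the name of the read-out) and lower numbers for less inhibition), 4%.
Compound 2 `OC[C@H]1O[C@@H](n2cnc3c(S)nccc32)C[C@@H]1O` gives in this assay 10%.
Compound 3 `OC[C@H]1O[C@@H](n2cnc3c(SCc4ccccc4)nccc32)C[C@@H]1O` gives in this assay 18%.

Compound 3 carries the highest of the three numbers; its gap to compound 2 lies within the scatter, while a number 14 percentage points higher from compound 1 to compound 3 (beyond the scatter) lies beyond it. Compound 4 `OC[C@H]1O[C@@H](n2cnc3cnccc32)C[C@@H]1O` differs from compound 3 in one place: hydrogen in place of benzylsulfanyl on an aromatic carbon. Among the compounds with values here, no measured step puts hydrogen on this aromatic carbon, so the bearings are indirect: a number 8 percentage points higher from compound 2 to compound 3 (within the scatter), and a number 14 percentage points higher from compound 1 to compound 3 (beyond the scatter). Both suggest the unsubstituted compound should sit near the low end of the series, and a small downward step in this assay, close to the edge of the scatter, is expected: a number 10 percentage points lower from compound 3 to compound 4 (within the scatter). Compound 4 is estimated at 8%, with a range from 0% to 20%.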

Compound 4, a percentage reported as inhibition, at one concentration (the size of the read-out at that concentration, not a potency): 6%
The estimate for compound 4 lay 2 percentage points above the measured number; measured number inside the range.
By their numbers in this assay, from the lowest: compounds 1, 4, 2 and 3 (each within the scatter of the next, the first and the last beyond it).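

On this aromatic carbon, a number 12 percentage points lower from compound 3 to compound 4 (beyond the scatter) sets benzylsulfanyl apart from plain hydrogen in this assay while a number 4 percentage points lower from compound 2 to compound 4 (within the scatter) and a number 2 percentage points higher from compound 1 to compound 4 (within the scatter) leave sulfanyl and azido unseparated from hydrogen. Of the three groups compared with hydrogen here, only benzylsulfanyl gives a step beyond the scatter, and that step is modest. Nothing at hand bears on the reason for this step.

Going by these compounds, whether an amine, a methoxy group or a longer alkylsulfanyl chain on this carbon would move the number further stays open. Also open, on these data alone, is whether the aromatic ring of benzylsulfanyl is needed for the step.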